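A few compounds are considered here, and "the series" means these few. Any claim that something is new, unique, unknown or untested is made for them only; others in the source may bear on it.

Compound 2 `Cn1nc(-c2ccnc(Nc3ccc(Cl)cc3)n2)c2ccccc21` gives 7830 nM in a functional assay on MCF7 cells (Homo sapiens) for antiproliferative activity, read by MTT assay, with a stated time of 72 h (on this read-out lower numbers stand for stronger inhibition of growth and higher numbers for weaker inhibition of growth), the lower of the two numbers shown, separated from compound 1 `Cn1nc(-c2ccnc(Nc3ccc(O)cc3)n2)c2ccccc21` by a gap within the scatter; compound 1 gives 8910 nM in this assay. Among the measured compounds shown here, the single step between them, a 1.1-fold lower number from compound 1 to compound 2 (0.06 log units; within the scatter), exchanged the group at the same place and stayed within the scatter. Compound 3 `Cn1nc(-c2ccnc(Nc3ccc([N+](=O)[O-])cc3)n2)c2ccccc21` carries nitro in place of chloro on an aromatic carbon. For the measured compounds named here, because the only comparable step a 1.1-fold lower number from compound 1 to compound 2 (0.06 log units; within the scatter) was within the scatter, for compound 3 no change beyond the scatter is expected, a 1.0-fold lower number from compound 2 to compound 3 (0.02 log units; within the scatter). Compound 3 is therefore estimated at 7500 nM, with a range from 2500 nM to 22000 nM.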

Compound 3, concentration for 50% growth inhibition: 11800 nM
Compound 3: middle estimate off by 1.6-fold (0.20 log units), on the low side; the range from low to high includes it.
By their numbers in this assay, from the lowest: compounds 2, 1 and 3 (each within the scatter of the next).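

At this place, on an aromatic carbon para to a large group, nitro joins hydroxy and chloro, and this assay still separates none of the three: a 1.5-fold higher number from compound 2 to compound 3 (0.18 log units; within the scatter) and a 1.3-fold higher number from compound 1 to compound 3 (0.12 log units; within the scatter) both lie within the scatter. The exchange of chloro for nitro brings in hydrogen-bond acceptors, yet the number does not move beyond the scatter. No evidence on the reason for this is available. On these data alone, whether an amine, a carboxylic acid or a longer chain at this place would move the number beyond the scatter remains open. So does the effect of any change elsewhere on the shared core.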